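Diarylamine series: dropping one trifluoromethyl from compound 2

This account rests on a few compounds, and the source may have more. Where it says the series, first, only, none or still open, it means among the compounds named here.

Of the compounds shown here, two have numbers so far. Compound 1 `Cc1cc(C)c(Nc2ccc(Cl)c(C(F)(F)F)c2)c(C)c1` and compound 2 `Cc1cc(C)c(Nc2cc(C(F)(F)F)cc(C(F)(F)F)c2)c(C)c1` share the same core and differ only in the substitution of the second aromatic ring. In an assay on isolated protein for binding affinity to Rap guanine nucleotide exchange factor 4 (Homo sapiens), read by cAMP accumulation (on this read-out lower numbers stand for stronger inhibition and higher numbers for weaker inhibition), compound 1 gives 400 nM, and in this assay compound 2 gives 600 nM. The gap between these two numbers is within the usual scatter, so neither compound is set apart from the other; compound 2 simply stands at one of two closely placed numbers.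

The next compound, compound 3 `Cc1cc(C)c(Nc2cccc(C(F)(F)F)c2)c(C)c1`, takes compound 2 and removes one substituent: hydrogen in place of trifluoromethyl on an aromatic carbon. Going by the values given here, no step between measured compounds covers this change, so its size cannot be read from the numbers at hand. Both measured compounds carry two groups on that ring, and compound 3 keeps only one; a modest loss is expected rather than a gain.

The step expected a 2.0-fold higher number from compound 2 to compound 3 (0.30 log units; within the scatter) is small, at the edge of the scatter. Compound 3 is expected at 1200 nM, with a range from 500 nM to 3000 nM.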

Compound 3, half-maximal inhibitory concentration: 2000 nM
Estimate against measurement, compound 3: 1.7-fold (0.22 log units) below, within the range that was stated.
By their numbers in this assay, from the lowest: compounds 1 and 2 (each within the scatter of the next); then compound 3.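

Within this assay, taking away the trifluoromethyl that sits meta to a trifluoromethyl group is a real loss (a 3.3-fold higher number from compound 2 to compound 3 (0.52 log units; beyond the scatter)), and the two earlier compounds, whose values lie within the scatter of each other, could not show this. Hydrogen in place of chloro moves the number the same way (a 5.0-fold higher number from compound 1 to compound 3 (0.70 log units; beyond the scatter)), also beyond the scatter, so among these three compounds a second group on that ring, whether trifluoromethyl or chloro, goes with a lower number than hydrogen, and none of the three goes against this. Nothing in hand explains why the number rises with either change.

As far as these compounds go, all three compounds keep one trifluoromethyl on that ring and the same methyl groups on the other, so what those groups contribute stays open. From the compounds shown here alone, it is also open whether the second group must be a halogen-bearing one, or whether a nitrile, a methoxy group or an amine in that place would give numbers like those of compound 1 and compound 2.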